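The source may report more compounds than this note shows. Statements on the series, on what has been measured and on what is new or still open speak of the compounds shown alone.

Three compounds have so far been measured in an assay on isolated protein for inhibition of aldehyde dehydrogenase 1A1 (Homo sapiens), read by spectrophotometry, tested at 10 uM; a lower number here means less inhibition, a higher number more inhibition at the concentration tested (going by the name of the read-out):

Compound 1, `CC(C)=CCn1c(CN2CCN(C(=O)C3CC3)CC2)nc2ccccc21`, gives 74.3%.
Compound 2, `Cc1cccc(Cn2c(OC3CCN(C(=O)C4CC4)CC3)nc3ccccc32)c1`, gives 80.6%.
Compound 3, `COc1ccc(C(=O)N2CCN(Cc3nc4ccccc4n3Cc3cccc(C)c3)CC2)cc1`, gives 55.5%.

Among these three numbers compound 1 stands second highest. Its nearest neighbour is compound 2, whose number is higher by an amount that lies within the scatter of repeated measurements, so the two cannot be told apart. The furthest is compound 3, whose number is lower by a gap that lies beyond the scatter.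

Compound 4, `Cc1ccccc1Cn1c(CN2CCN(C(=O)C3CC3)CC2)nc2ccccc21`, has not yet been measured. It differs from compound 1 in a single place: 2-methylphenyl in place of 2-methylprop-1-en-1-yl on a saturated chain carbon bound to an aromatic nitrogen. Both the group that leaves and the group that enters are built of carbon only, with no hydrogen-bond donors or acceptors. Compound 2 and compound 3 each carry an aromatic ring on a chain at the corresponding nitrogen, and their two values show that such a ring is compatible with inhibition, but each of them also differs from compound 1 elsewhere, so no clean step can be read from them. The step from compound 1 to compound 4 is expected to be a number 0.3 percentage points lower from compound 1 to compound 4 (within the scatter), small and probably within the scatter, with its direction uncertain. Compound 4 is therefore expected to give about 74%, within a range from 55% to 90%.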

Compound 4, a percentage reported as inhibition, at one concentration (the size of the read-out at that concentration, not a potency): 29.1%
The estimate for compound 4 lay 44.9 percentage points above the measured number; measured number outside the range, below it.
By their numbers in this assay, from the lowest: compound 4; then compound 3; then compounds 1 and 2 (each within the scatter of the next).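

In this assay, within the data shown here, replacing 2-methylprop-1-en-1-yl with 2-methylphenyl on a saturated chain carbon bound to an aromatic nitrogen gives a number 45.2 percentage points lower from compound 1 to compound 4 (beyond the scatter), the first step here that isolates this position. It shows that inhibition depends strongly on the group held at this place, even though both groups are built of carbon only and carry no hydrogen-bond donors or acceptors. No measurement is available that explains the size of this step.

The compounds shown leave open whether the lower inhibition goes with the aromatic ring itself or with its methyl group, a question that an unsubstituted benzyl group on the same carbon framework would address. A saturated 3-methylbutyl chain would likewise show whether the double bond of compound 1 matters for inhibition.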